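A few compounds are considered here, and "the series" means these few. Any claim that something is new, unique, unknown or untested is made for them only; others in the source may bear on it.

Measured so far in a functional assay on K562 cells (Homo sapiens) for antiproliferative activity, read by sulforhodamine B assay, with a stated time of 48 h, tested at 50 uM; on this read-out higher numbers stand for more inhibition at the one concentration tested (going by the name of the read-out) and lower numbers for less inhibition:
- compound 1 `Cc1cc2c(C(C)C)ccc(C)c2cc1OC(=O)c1cccc(C(F)(F)F)c1`: "not active" (no number reported)
- compound 2 `CC1=CC[C@H](C(C)C)c2cc(C)c(OC(=O)Nc3ccccc3)cc21`: 92.6%
- compound 3 `Cc1cc2c(C(C)C)ccc(C)c2cc1OC(=O)c1ccc(C(F)(F)F)cc1`: 45.1%

Compound 2 stands highest of the two numbers reported in this assay, and its gap to compound 3 is well beyond the scatter of this kind of measurement. Compound 1 gave no number at all, only the word that it was not active. Compound 3 and compound 1 both carry an aromatic ring joined directly to the carbonyl carbon, whereas compound 2 carries an anilino group there; compound 2 also differs from the other two in its shared core, so no clean single-step comparison is available among the measured compounds.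

Compound 4 `CC1=CC[C@H](C(C)C)c2cc(C)c(OC(=O)c3cccc(Cl)c3)cc21` keeps the core of compound 2 and changes only the group on the carbonyl carbon: 3-chlorophenyl in place of anilino on a carbonyl carbon. With the two aromatic esters on the other core giving either a modest number, as compound 3 does with 45.1%, or nothing, the step from compound 2 to compound 4 is expected to be downward and beyond the scatter, by about a number 37.6 percentage points lower from compound 2 to compound 4 (beyond the scatter). Compound 4 is therefore estimated at 55%, with a plausible range from 20% to 85%.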

Compound 4, a percentage reported as inhibition, at one concentration (the size of the read-out at that concentration, not a potency): "not active" (no number reported)
Nothing numeric was reported for compound 4; no gap can be computed for the estimate.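

In this assay compound 4 gives "not active" (no number reported) without a number, so the change from compound 2 to compound 4 cannot be read as a step of any size. No measurement shown offers an explanation for this result. The compounds shown leave open how far the anilino group itself accounts for the inhibition seen with compound 2.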